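Carboxy in place of the ester chain of compound 1

The source may hold more compounds than are shown below. What is called first, only, known or untested is meant among the compounds shown, and "the series" means these compounds.

Among the measured compounds shown here, in an in vivo functional assay on the whole organism for inhibition, with Rattus norvegicus as the target (a higher number here means that more compound is needed for the effect, a lower number that less compound is needed), compound 1 (`CCCCc1nc(C)c(CCC(=O)OCC)c(=O)n1Cc1ccc(-c2ccccc2-c2nnn[nH]2)cc1`) gives 0.066 mg/kg as the only number so far. Compound 2 (`CCCCc1nc(CCC)c(CCC(=O)OCC)c(=O)n1Cc1ccc(-c2ccccc2-c2nnn[nH]2)cc1`) stands as "not determined" (no result reported) and offers no comparison. Compound 3 (`CCCCc1nc(C)c(CC(=O)O)c(=O)n1Cc1ccc(-c2ccccc2-c2nnn[nH]2)cc1`) differs from compound 1 by one change (carboxy in place of (ethoxycarbonyl)methyl on a saturated chain carbon bound to an aromatic carbon) with carboxy in place of (ethoxycarbonyl)methyl on a saturated chain carbon bound to an aromatic carbon. For the measured compounds named here, no measured step covers this change, so the expectation stays loose. A moderate step toward more compound needed in this assay is expected, estimated as a 3.0-fold higher number from compound 1 to compound 3 (0.48 log units; beyond the scatter) with wide uncertainty. For compound 3 the estimated value is 0.2 mg/kg with 0.04 mg/kg and 1 mg/kg as the expected ends of the range.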

Compound 3, dose for half-maximal effect: 0.13 mg/kg
For compound 3 the middle estimate is 1.5-fold (0.19 log units) above the measured one, and the stated range covers the measured number.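

In this assay, the exchange of (ethoxycarbonyl)methyl for carboxy on a saturated chain carbon bound to an aromatic carbon gives a 2.0-fold higher number from compound 1 to compound 3 (0.29 log units; within the scatter). This position therefore accepts both the ester chain and the free carboxy end without a separable difference in dose. No data bearing on the origin of this result are available.

The step alters the chain and the ester together, so their separate contributions stay unresolved, and a 2-carboxyethyl group would be needed to tell them apart. From the compounds shown here alone, how a primary amide or a tetrazole at this position would read also remains open.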